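The source may report more compounds than this note shows. Statements on the series, on what has been measured and on what is new or still open speak of the compounds shown alone.

Among the compounds with values here, compound 2 `Cc1cc2c(c(N)nn2C)c(N2CCCCC2)n1` is one of two compounds measured in an assay on isolated protein for inhibition of RAC-alpha serine/threonine-protein kinase (Homo sapiens), read by mobility shift assay, tested at 30 uM (a higher number here means more inhibition at the concentration tested (going by the name of the read-out), a lower number less inhibition), where compound 2 gives 6%, the lower of the two numbers. Within the data shown here, the other is compound 1 `Cc1cc2[nH]nc(N)c2c(N2CCCCC2)n1`, which in this assay gives 36%; the single measured step, a number 30 percentage points lower from compound 1 to compound 2 (beyond the scatter), comes from methyl in place of hydrogen on an aromatic nitrogen. Compound 3 `Cc1cc2c(c(N)nn2C)c(N2CC[C@H](O)C2)n1` differs from compound 2 at a different place: 3-hydroxypyrrolidin-1-yl in place of piperidin-1-yl on an aromatic carbon. Among the measured compounds shown here, no measured step covers this place or this kind of exchange, so the one known step gives no guide to the size or direction of the change. Without such a guide, the expectation for compound 3 in this assay is a step within the scatter, a number 4 percentage points higher from compound 2 to compound 3 (within the scatter). Compound 3 is therefore estimated to give 10% in this assay, with a range from -5% to 35% kept wide for want of a matching comparison.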

Compound 3, a percentage reported as inhibition, at one concentration (the size of the read-out at that concentration, not a potency): 7%
Estimate against measurement, compound 3: 3 percentage points above; measured number inside the range.
By their numbers in this assay, from the lowest: compounds 2 and 3 (each within the scatter of the next); then compound 1.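

At the aromatic carbon next to the ring nitrogen, with the methyl already on the aromatic nitrogen, changing the six-membered piperidin-1-yl ring to the five-membered 3-hydroxypyrrolidin-1-yl ring gives a number 1 percentage points higher from compound 2 to compound 3 (within the scatter) in this assay. So this exchange, which also brings in a hydroxyl group and a defined stereocentre, leaves the read-out unmoved on this core, but compound 2 and compound 3 both sit low on the scale, where a further fall would have little room to show. No measurement on hand explains this result.

From the compounds shown here alone, whether the same exchange would matter on the core of compound 1, which has hydrogen on that aromatic nitrogen, remains open. So does the effect at this position of a morpholin-4-yl ring, a 4-aminopiperidin-1-yl ring or the mirror-image 3-hydroxypyrrolidin-1-yl group.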